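The source may report more compounds than this note shows. Statements on the series, on what has been measured and on what is new or still open speak of the compounds shown alone.

Compound 1 `CCOC(=O)C1=Cc2ccccc2OC1(OCc1cc(-c2ccc(F)cc2F)no1)C(F)(F)F`; compound 2 `CCOC(=O)C1=Cc2ccccc2OC1(OCc1cn(CC(=O)Nc2cccc(Cl)c2)nn1)C(F)(F)F`; compound 3 `CCOC(=O)C1=Cc2ccccc2OC1(OCc1cc(-c2ccc(C)cc2)no1)C(F)(F)F`.

In a functional assay on A549 cells (Homo sapiens) for inhibition, read by MTT assay, with a stated time of 24 h (a higher number here means a weaker inhibitor, a lower number a stronger inhibitor), compound 1 gives > 150000 nM, which is a limit of the assay and not a number. Compound 2 gives 12800 nM. Compound 3 gives > 150000 nM, again a limit. For the measured compounds named here, compound 2 therefore stands as the only compound with a real number; the other two values sit at the limit of > 150000 nM in this assay, at which 2 of the 3 values shown sit. Going by the values given here, the one step between measured compounds, a step that the two limits leave unreadable from compound 1 to compound 3, changes a ring on a different branch of the shared core and cannot be read in size, so nothing measured bears on the change now considered. Compound 4 `CCOC(=O)C1=Cc2ccccc2OC1(OCc1cn(CC(=O)NC2CCCCC2)nn1)C(F)(F)F` differs from compound 2 by cyclohexyl in place of 3-chlorophenyl on an amide-type nitrogen. Among the compounds with values here, with no measured step at this position, no shift beyond the scatter is expected, and the estimate for compound 4 is 20000 nM, with a range from 5000 nM to 150000 nM. The expected step is a 1.6-fold higher number from compound 2 to compound 4 (0.19 log units; within the scatter).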

Compound 4, half-maximal inhibitory concentration: 9900 nM
Compound 4: middle estimate off by 2.0-fold (0.31 log units), on the high side; the measured number falls inside the stated range.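

Putting cyclohexyl in place of 3-chlorophenyl on the amide-type nitrogen gives a 1.3-fold lower number from compound 2 to compound 4 (0.11 log units; within the scatter) in this assay. At this position, then, an aromatic ring is not required for a measurable number, and a ring of carbon only, aromatic or not, serves equally well in these two compounds. Nothing shown here explains this outcome.

Still open, from the compounds shown here alone, is whether a ring is needed at all, as a short chain such as ethyl could show. It is also unknown how a ring carrying an amine or a carboxylic acid would read at this position.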